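Methyl in Place of Methoxy: What Compound 4 Might Give

The compounds below may be only part of what the source reports. "The series", "measured", "known", "first", "only" and "open" are said of these compounds alone.

Compound 1 `C=CCSc1nc2c(c(=O)[nH]c(=O)n2C)n1CCC`: 5.5%
Compound 2 `CCCn1c(SCc2ccc(F)cc2)nc2c1c(=O)[nH]c(=O)n2C`: 86.5%
Compound 3 `CCCn1c(SCc2cccc(OC)c2)nc2c1c(=O)[nH]c(=O)n2C`: 34.2%

In a functional assay on MGC-803 cells (Homo sapiens) for inhibition, read by MTT assay, with a stated time of 48 h, tested at 20 uM (on this read-out lower numbers stand for less inhibition and higher numbers for more inhibition at the one concentration tested (going by the name of the read-out)), compound 3 stands second highest of the three numbers, with compound 1 nearest below it and compound 2 furthest above it. Compound 4 `CCCn1c(SCc2cccc(C)c2)nc2c1c(=O)[nH]c(=O)n2C` differs from compound 3 by methyl in place of methoxy on an aromatic carbon, so a 3-methylphenyl replaces the 3-methoxyphenyl. Going by the values given here, no measured step changes a group on this ring; the known steps, a number 81 percentage points higher from compound 1 to compound 2 (beyond the scatter), a number 28.7 percentage points higher from compound 1 to compound 3 (beyond the scatter) and a number 52.3 percentage points lower from compound 2 to compound 3 (beyond the scatter), concern the whole group on the sulfur. Among the compounds with values here, those steps show that aryl choice moves this read-out strongly, but a small swap on the ring has no precedent here, so compound 4 is expected to shift only modestly, a number 7.8 percentage points higher from compound 3 to compound 4 (within the scatter). Compound 4 is therefore estimated at 42%, between 15% and 72%.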

Compound 4, a percentage reported as inhibition, at one concentration (the size of the read-out at that concentration, not a potency): 84.1%
Compound 4: the middle estimate sits 42.1 percentage points below what was measured, outside the stated range (above it).
By their numbers in this assay, from the lowest: compound 1; then compound 3; then compounds 4 and 2 (each within the scatter of the next).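

In this assay, the change from methoxy to methyl on the aromatic ring turns out to be large (a number 49.9 percentage points higher from compound 3 to compound 4 (beyond the scatter)), so a single small substituent at this place can move the read-out as strongly as replacing the whole group on the sulfur. Compound 4 also matches the 4-fluorophenyl compound (a number 2.4 percentage points lower from compound 2 to compound 4 (within the scatter)) and stands well clear of the vinyl compound (a number 78.6 percentage points higher from compound 1 to compound 4 (beyond the scatter)), so among these compounds only compound 3 lags among the aryl groups. From the compounds shown here alone, what an amine or an ethyl group would give at this place stays open. No evidence at hand explains the gap between methoxy and methyl.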